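Adding a trifluoromethyl to the ring of compound 2

The compounds below may be only part of what the source reports. "The series", "measured", "known", "first", "only" and "open" are said of these compounds alone.

Of the compounds shown here, two from this series have been measured in an assay on CHO cells for displacement of a labelled ligand from histamine receptor H3 (Macaca mulatta); a higher number here means a weaker inhibitor, a lower number a stronger inhibitor. Compound 1 `CC1CCCN1C1CCN(c2ccc(NC(=O)C3C(C)(C)C3(C)C)cc2)C1` gives 144 nM in this assay, while compound 2 `CC1CCCN1C1CCN(c2ccc(NC(=O)C3CC3)cc2)C1` gives 9.7 nM. Within the data shown here, the one step between them, a 15-fold lower number from compound 1 to compound 2 (1.17 log units; beyond the scatter), is large and concerns only the group attached to the carbonyl carbon. On the numbers shown, compound 2 stands lowest of the two, with compound 1 the only neighbour, and that neighbour lies well beyond the scatter.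

Compound 3 `CC1CCCN1C1CCN(c2ccc(NC(=O)C3CC3)c(C(F)(F)F)c2)C1` is not yet measured. It differs from compound 2 in one place: trifluoromethyl in place of hydrogen on an aromatic carbon, ortho to a (cyclopropylcarbonyl)amino group and meta to a large group. Among the measured compounds shown here, no measured step touches this part of the structure; the single known step changed the acyl group, not the ring. There is therefore no measured basis to expect a shift in either direction beyond the scatter. For compound 3 the expected result in this assay is 12 nM, with a range from 4 nM to 40 nM. This estimate means a step of a 1.2-fold higher number from compound 2 to compound 3 (0.09 log units; within the scatter), which is expected to stay within the scatter.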

Compound 3, inhibition constant: 14.7 nM
For compound 3 the middle estimate is 1.2-fold (0.09 log units) below the measured one; the range from low to high includes it.
By their numbers in this assay, from the lowest: compounds 2 and 3 (each within the scatter of the next); then compound 1.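

The step in this assay for trifluoromethyl in place of hydrogen on this aromatic carbon, ortho to a (cyclopropylcarbonyl)amino group, is a 1.5-fold higher number from compound 2 to compound 3 (0.18 log units; within the scatter). Among these compounds, this is the first reading on the ring itself, and it shows that a group of 4 heavy atoms can stand at this position in place of a hydrogen with no change that can be told apart from the scatter of repeated measurements, in contrast to the only earlier step, a 15-fold lower number from compound 1 to compound 2 (1.17 log units; beyond the scatter), which lay on the other side of the molecule's amide, at the group on the carbonyl carbon. Nothing available bears on why this swap leaves the number where it is.

Going by these compounds, a single substituent at a single ring position says little about the position in general, so it remains open whether an amine, a carboxylic acid or a longer chain such as butyl would be accepted there as well. On these data alone, it is also open whether trifluoromethyl would behave the same way on the other ring carbons, or alongside the 2,2,3,3-tetramethylcyclopropyl group of compound 1.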